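Piperidinyl in Place of Furanyl: An Expectation

A few compounds are considered here, and "the series" means these few. Any claim that something is new, unique, unknown or untested is made for them only; others in the source may bear on it.

Of the compounds shown here, three have been measured in an assay on CHO cells for displacement of a labelled ligand from Substance-P receptor (Homo sapiens); on this read-out lower numbers stand for stronger inhibition and higher numbers for weaker inhibition. For the measured compounds named here, compound 1 `COc1ccccc1N1CCN(C(=O)CCc2c(-c3ccc(Cl)cc3)[nH]c3cc(Cl)ccc23)CC1` gives 4.9 nM, and compound 2 `COc1ccccc1N1CCN(C(=O)CCc2c(-c3ccc(Cl)cc3)[nH]c3cc(Cl)cc(Cl)c23)CC1` gives 570 nM; the only one-place step among the measured compounds, a 120-fold higher number from compound 1 to compound 2 (2.07 log units; beyond the scatter), concerns a chloro in place of hydrogen on an aromatic carbon. Compound 3 `Cn1c(-c2ccc(Cl)cc2)c(CCC(=O)N2CCC(O)(Cc3ccccc3)CC2)c2cc(-c3ccco3)ccc21` gives 0.79 nM, the lowest of the three numbers. Compound 4 `Cn1c(-c2ccc(Cl)cc2)c(CCC(=O)N2CCC(O)(Cc3ccccc3)CC2)c2cc(N3CCCCC3)ccc21` differs from compound 3 by piperidin-1-yl in place of furan-2-yl on an aromatic carbon. Going by the values given here, no measured step bears directly on this change, since the chloro step involves a different group at a different place, and the measured set offers no guide to swapping these two rings. Compound 4 is therefore expected to stay close to its parent, with no step beyond the scatter, a 1.9-fold higher number from compound 3 to compound 4 (0.28 log units; within the scatter). Compound 4 is estimated at 1.5 nM, within a range from 0.4 nM to 6 nM.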

Compound 4, half-maximal inhibitory concentration: 3.3 nM
For compound 4 the middle estimate is 2.2-fold (0.34 log units) below the measured one; the range from low to high includes it.
By their numbers in this assay, from the lowest: compound 3; then compounds 4 and 1 (each within the scatter of the next); then compound 2.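

In this assay, piperidin-1-yl in place of furan-2-yl on this aromatic carbon gives a 4.2-fold higher number from compound 3 to compound 4 (0.62 log units; beyond the scatter), a modest step that lies beyond the scatter. The place therefore accepts a six-membered non-aromatic ring as well as a five-membered aromatic one, at a modest cost and with the number still in the low range of the set. Going by these compounds, whether an open-chain amine such as dimethylamino, or a plain phenyl ring, would stand nearer to compound 3 or to compound 4 stays open. What lies behind the step also stays open, since nothing available here bears on it.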